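A few compounds are considered here, and "the series" means these few. Any claim that something is new, unique, unknown or untested is made for them only; others in the source may bear on it.

Going by the values given here, compound 2 `CCC(=O)N1CC2CC(C1)N2` stands at the lower of the two numbers known in an assay on SH-EP1 cells for displacement of a labelled ligand from Neuronal acetylcholine receptor; alpha4/beta2 (Homo sapiens), read by scintillation counting (on this read-out higher numbers stand for weaker inhibition and lower numbers for stronger inhibition), where it gives 6 nM; compound 1 `CC(=O)N1CC2CC(C1)N2` gives 150 nM. Among the compounds with values here, the only measured step, a 25-fold lower number from compound 1 to compound 2 (1.40 log units; beyond the scatter), was large. Compound 3 `O=C(C1CCC1)N1CC2CC(C1)N2` follows from compound 2 by cyclobutyl in place of ethyl on a carbonyl carbon. Within the data shown here, this again enlarges the group on the carbonyl carbon, but no measured step covers a change of this kind, so the earlier step is only a loose guide. For compound 3 the expected step is a 1.5-fold lower number from compound 2 to compound 3 (0.18 log units; within the scatter), a small lowering or none beyond the scatter. Compound 3 is therefore estimated at 4 nM, within 1.2 nM to 13 nM.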

Compound 3, inhibition constant: 16 nM
Beside the measured number, compound 3's estimate is 4.0-fold (0.60 log units) below it; measured number above the stated range.
By their numbers in this assay, from the lowest: compound 2; then compound 3; then compound 1.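

In this assay, a larger group on the carbonyl carbon does not keep lowering the number: cyclobutyl in place of ethyl gives a 2.7-fold higher number from compound 2 to compound 3 (0.43 log units; beyond the scatter) and so turns the earlier trend back. Cyclobutyl in place of methyl still gives a 9.4-fold lower number from compound 1 to compound 3 (0.97 log units; beyond the scatter) and keeps part of the gain, which leaves ethyl with the lowest number of the three groups shown. Nothing given here accounts for this turn.

Going by these compounds, whether a longer chain such as propyl would lie closer to compound 2 or to compound 3 remains open. So does the effect of an amine on the carbonyl carbon.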